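The source may hold more compounds than are shown below. What is called first, only, known or untested is meant among the compounds shown, and "the series" means these compounds.

Two compounds of the series have a number in an ADME assay on microsomes from liver (Homo sapiens) for metabolic stability, with a stated time of 60 min, tested at 1 uM; on this read-out lower numbers stand for a less stable compound and higher numbers for a more stable compound. Compound 1 `Cn1cc(-c2nc3c(-c4ccnc(OC5CC5)c4)cnn3cc2OCC(C)(C)O)cn1` gives 53% there. Compound 2 `COc1cc(-c2cnn3cc(OC)c(C)nc23)ccn1` gives 44% in this assay; the gap to compound 1 lies within the scatter of repeated runs, so the two stand at the same level on this read-out and neither can be called more stable than the other. The unmeasured compound 3 `COc1cc(-c2cnn3cc(OC)c(N(C)C)nc23)ccn1` keeps the core of compound 2 and differs from it in a single place: dimethylamino in place of methyl on an aromatic carbon. Within the data shown here, no step between measured compounds resembles this change, so the expectation rests on the value of compound 2 alone. A step of a number 12 percentage points lower from compound 2 to compound 3 (beyond the scatter) in this assay is expected, downward, of a size somewhat beyond the scatter but not large. Compound 3 is accordingly estimated at 32%, with a range from 12% to 55%.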

Compound 3, percent of the compound remaining: 16%
The estimate for compound 3 lay 16 percentage points above the measured number, and the stated range covers the measured number.
By their numbers in this assay, from the lowest: compound 3; then compounds 2 and 1 (each within the scatter of the next).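

At this position, the aromatic carbon next to the ring nitrogen and ortho to a methoxy group, dimethylamino in place of methyl gives a number 28 percentage points lower from compound 2 to compound 3 (beyond the scatter) in this assay. Among these compounds, this is the only single-place step available, and it shows that stability on this read-out depends on the group at this carbon. The change replaces a group of carbon alone with one that brings in a nitrogen and a hydrogen-bond acceptor, but the data do not show why the number falls.

As far as these compounds go, whether the step follows the nitrogen or the added carbons stays open; an amine, methylamino or ethyl group on the same carbon would separate the two. Also open, from the compounds shown here alone, is whether dimethylamino has the same effect alongside the other groups of compound 1.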